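A few compounds are considered here, and "the series" means these few. Any claim that something is new, unique, unknown or untested is made for them only; others in the source may bear on it.

Compound 3 `CCc1ccc(NC2=CC(=O)c3nc4n(c3C2=O)[C@H]2OC[C@@H](O)[C@H]2OC4)cc1` gives 3990 nM in a functional assay on HeLa cells (Homo sapiens) for inhibition, read by sulforhodamine B assay (a lower number here means a stronger inhibitor, a higher number a weaker inhibitor), the highest of the two numbers shown, though its gap to compound 1 `Cc1ccc(NC2=CC(=O)c3nc4n(c3C2=O)[C@H]2OC[C@@H](O)[C@H]2OC4)cc1C`, which gives 2690 nM, stays within the scatter. Compound 2 `O=C1C=C(NCc2ccccc2)C(=O)c2c1nc1n2[C@H]2OC[C@@H](O)[C@H]2OC1` reaches only the limit > 8000 nM in this assay. Compound 4 `O=C1C=C(Nc2ccccc2)C(=O)c2c1nc1n2[C@H]2OC[C@@H](O)[C@H]2OC1` differs from compound 3 by hydrogen in place of ethyl on an aromatic carbon. Going by the values given here, two measured steps bear on this: a 1.5-fold higher number from compound 1 to compound 3 (0.17 log units; within the scatter), and an at least 2.0-fold lower number from compound 2 to compound 3 (0.30 log units; that floor lies within the scatter), a larger swap than the one at hand. Given the small size of a 1.5-fold higher number from compound 1 to compound 3 (0.17 log units; within the scatter), the expected step of a 1.3-fold higher number from compound 3 to compound 4 (0.10 log units; within the scatter) is modest, perhaps a slight rise, within or near the scatter. Compound 4 is therefore estimated to give about 5000 nM in this assay, most likely between 2000 nM and 12000 nM.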

Compound 4, half-maximal inhibitory concentration: 5620 nM
For compound 4 the middle estimate is 1.1-fold (0.05 log units) below the measured one, and the stated range covers the measured number.
By their numbers in this assay, from the lowest: compounds 1, 3 and 4 (each within the scatter of the next, the first and the last beyond it). At a limit, above all of these: compound 2.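

Removing the ethyl from the 4-ethylphenyl group gives a 1.4-fold higher number from compound 3 to compound 4 (0.15 log units; within the scatter), so this single change at this position cannot be told apart from scatter. The wider change, from 3,4-dimethylphenyl to unsubstituted phenyl, gives a 2.1-fold higher number from compound 1 to compound 4 (0.32 log units; beyond the scatter), so the two ends of this small series do separate, though only modestly. The figure for compound 2 is a limit, so an at least 1.4-fold lower number from compound 2 to compound 4 (0.15 log units; that floor lies within the scatter) does not separate phenyl from benzyl on the amine nitrogen.

Open, as far as these compounds go, is what an amine, a carboxylic acid or a chain longer than ethyl would do at this position. Also open, from the compounds shown here alone, is whether any group there could bring the number clearly below that of compound 1.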